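Series notes: alpha-substituent on the amino-acid benzylamide

The compounds below may be only part of what the source reports. "The series", "measured", "known", "first", "only" and "open" are said of these compounds alone.

Compound 1 `CCCC(N)C(=O)NCc1ccccc1`, compound 2 `CCC[C@@H](N)C(=O)NCc1ccccc1` and compound 3 `CCCC[C@@H](N)C(=O)NCc1ccccc1` share one core and differ only at the saturated chain carbon bound to the amine nitrogen and the carbonyl carbon. In a functional assay on the whole organism (strain NMRI) with Mus musculus as the target, in the maximal electroshock model, with a stated time of 30 min (on this read-out higher numbers stand for an effect only at larger amounts of compound and lower numbers for an effect already at smaller amounts), compound 1 gives 39 mg/kg, compound 2 gives 21 mg/kg and compound 3 gives 23 mg/kg. Both measured steps, a 1.9-fold lower number from compound 1 to compound 2 (0.27 log units; within the scatter) and a 1.1-fold higher number from compound 2 to compound 3 (0.04 log units; within the scatter), lie within the scatter; the first rests on (the fact that one of compounds 1 and 2 is drawn with a defined configuration and the other without, at the place where they differ). Compound 3 stands second highest of the three numbers, nearest compound 2 and furthest from compound 1, both within the scatter.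

Compound 4 `N[C@@H](C(=O)NCc1ccccc1)C1CCCCC1` follows from compound 3 by cyclohexyl in place of butyl on a saturated chain carbon bound to an amine nitrogen and a carbonyl carbon. Among the compounds with values here, only the step from compound 2 to compound 3 bears on it, and that step was within the scatter, so no step beyond the scatter is expected in this assay: no change at the digits printed from compound 3 to compound 4 (within the scatter). Compound 4 is therefore estimated at 23 mg/kg, between 10 mg/kg and 55 mg/kg.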

Compound 4, dose for half-maximal effect: 28 mg/kg
For compound 4 the middle estimate is 1.2-fold (0.09 log units) below the measured one, within the range that was stated.
By their numbers in this assay, from the lowest: compounds 2, 3, 4 and 1 (each within the scatter of the next).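

The first ring at this position, a six-membered non-aromatic ring of carbon only, leaves the read-out in this assay unchanged within the scatter: a 1.2-fold higher number from compound 3 to compound 4 (0.09 log units; within the scatter) with cyclohexyl in place of butyl, and a 1.3-fold higher number from compound 2 to compound 4 (0.12 log units; within the scatter) with cyclohexyl in place of propyl. Open chain and ring thus cannot be told apart here, and neither can these substituent sizes. Nothing available gives a cause for this result.

From the compounds shown here alone, it remains open whether a phenyl, a carboxylic acid, an amine or a longer chain on this saturated chain carbon would give a step beyond the scatter.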